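Swapping butyl for 3-(piperidin-1-yl)propyl on the shared core

A few compounds are considered here, and "the series" means these few. Any claim that something is new, unique, unknown or untested is made for them only; others in the source may bear on it.

Of the compounds shown here, three sharing one core have been tested in an ADME assay on HEK293 cells (Homo sapiens) for cytotoxicity, read by MTT assay, with a stated time of 48 h; on this read-out lower numbers stand for stronger inhibition and higher numbers for weaker inhibition. Compound 1 `Cn1c(N)c(-c2nc3ccccc3[nH]2)c2nc(C#N)c(C#N)nc21` gives > 50000 nM, which is a limit of the assay and not a number. Compound 2 `CCCn1c(N)c(-c2nc3ccccc3[nH]2)c2nc(C#N)c(C#N)nc21` gives > 50000 nM, again a limit. Compound 3 `CCCCn1c(N)c(-c2nc3ccccc3[nH]2)c2nc(C#N)c(C#N)nc21` gives > 50000 nM, also a limit. Compound 3 thus shares its place with the others: the limit of > 50000 nM in this assay, at which 3 of the 3 values shown sit.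

Compound 4 `N#Cc1nc2c(-c3nc4ccccc4[nH]3)c(N)n(CCCN3CCCCC3)c2nc1C#N` changes the chain of compound 3: piperidin-1-yl in place of methyl on a saturated chain carbon, three bonds along the chain from an aromatic nitrogen. This puts piperidin-1-yl in place of methyl on a saturated chain carbon, three bonds along the chain from an aromatic nitrogen.

Among the compounds with values here, three measured steps bear on this chain: a step that the two limits leave unreadable from compound 1 to compound 2, a step that the two limits leave unreadable from compound 1 to compound 3 and a step that the two limits leave unreadable from compound 2 to compound 3. Within the data shown here, none gives a size, so they show only that a longer plain chain brought no compound to a number. The ring is new to these compounds, so a modest move towards stronger inhibition is expected, though another limit is quite possible. The expected change is an at least 1.6-fold lower number from compound 3 to compound 4 (0.22 log units; that floor lies within the scatter), and this is only a rough estimate. For compound 4 the estimated value is 30000 nM, with an expected range of 8000 nM to 50000 nM.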

Compound 4, half-maximal inhibitory concentration: 6720 nM
Compound 4: the middle estimate sits 4.5-fold (0.65 log units) above what was measured; the measured number lies below the stated range.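

In this assay piperidin-1-yl in place of methyl on a saturated chain carbon, three bonds along the chain from an aromatic nitrogen, gives a step that can be read (an at least 7.4-fold lower number from compound 3 to compound 4 (0.87 log units; beyond the scatter)). The shorter chains give the same picture (an at least 7.4-fold lower number from compound 2 to compound 4 (0.87 log units; beyond the scatter); an at least 7.4-fold lower number from compound 1 to compound 4 (0.87 log units; beyond the scatter)), and each of these steps is a floor, as it starts from a limit. The steps among compound 1, compound 2 and compound 3 cannot be read, so only the chain ending in piperidin-1-yl brings a compound off the limit: the limit of > 50000 nM in this assay, at which 3 of the 4 values shown sit.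

The compounds shown leave open whether the ring or its nitrogen matters more, which a dimethylamino group or a morpholine ring in place of piperidin-1-yl could help to separate. They also leave open how the step changes with a longer chain carrying piperidin-1-yl, or with 2-(piperidin-1-yl)ethyl.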